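This account rests on a few compounds, and the source may have more. Where it says the series, first, only, none or still open, it means among the compounds named here.

All four compounds share one core and differ in the group on an aromatic carbon of the five-membered ring with three nitrogens. Compound 1 `CC(C)(C)c1cn(C[C@H](O)[C@H]2OC(=O)C(OCc3ccccc3)=C2OCc2ccccc2)nn1` carries a tert-butyl there. In a functional assay on HCT-116 cells (Homo sapiens) for antiproliferative activity, read by MTT assay, with a stated time of 72 h (a higher number here means a weaker inhibitor, a lower number a stronger inhibitor), compound 1 gives 28300 nM. Compound 2 `COc1ccc(-c2cn(C/C=C3\OC(=O)C(OCc4ccccc4)=C3OCc3ccccc3)nn2)cc1` differs in its linker and carries an aryl group. For compound 2 this assay reports only a limit, > 100000 nM. Compound 3 `COc1ccccc1-c1cn(C[C@H](O)[C@H]2OC(=O)C(OCc3ccccc3)=C2OCc2ccccc2)nn1` carries a 2-methoxyphenyl. For compound 3 this assay reports only a limit, > 100000 nM. Compound 3 therefore stands at the weak end of the numbers shown, sharing the limit of > 100000 nM in this assay, at which 2 of the 3 values shown sit, with compound 2, and the single measured step, an at least 3.5-fold higher number from compound 1 to compound 3 (0.54 log units; beyond the scatter), is the one that leads to it.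

Compound 4 `CCCCc1cn(C[C@H](O)[C@H]2OC(=O)C(OCc3ccccc3)=C2OCc2ccccc2)nn1` is the next compound, and it differs from compound 3 in one place: butyl in place of 2-methoxyphenyl on an aromatic carbon. Among the measured compounds shown here, the only step that bears on this change is the one from compound 1 to compound 3, which exchanged an alkyl for this same aryl and gave an at least 3.5-fold higher number from compound 1 to compound 3 (0.54 log units; beyond the scatter). Compound 4 reverses that exchange, though with butyl rather than tert-butyl, so a lower number of about that size is expected, an at least 2.5-fold lower number from compound 3 to compound 4 (0.39 log units; beyond the scatter). Compound 4 is therefore estimated at 40000 nM, with a range from 15000 nM to 100000 nM.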

Compound 4, half-maximal inhibitory concentration: 10400 nM
Beside the measured number, compound 4's estimate is 3.8-fold (0.59 log units) above it; measured number below the stated range.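

Until now, this aromatic carbon had shown only that 2-methoxyphenyl gives a weaker result than tert-butyl; butyl in place of 2-methoxyphenyl now gives an at least 9.6-fold lower number from compound 3 to compound 4 (0.98 log units; beyond the scatter), so an alkyl group without a ring restores activity here. The new compound also shows that the kind of alkyl group matters and not just the absence of the aryl ring: butyl in place of tert-butyl gives a 2.7-fold lower number from compound 1 to compound 4 (0.43 log units; beyond the scatter), which makes compound 4, at 10400 nM, the strongest of the compounds that differ only at this carbon. The true size of the first step remains unknown, as compound 3 has only a limit in this assay: the limit of > 100000 nM in this assay, at which 2 of the 4 values shown sit.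

The compounds shown leave open whether a longer chain, such as hexyl or octyl, would lower the number further or whether butyl is already close to the best length. It is also unclear how this position would respond to a chain ending in an amine or a carboxylic acid, or to a phenyl ring without the methoxy group.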